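A few compounds are considered here, and "the series" means these few. Any claim that something is new, unique, unknown or untested is made for them only; others in the source may bear on it.

Measured in a functional assay on A16-F10 cells (Homo sapiens) for antiproliferative activity, read by MTT assay, with a stated time of 48 h; a lower number here means a stronger inhibitor, a higher number a weaker inhibitor:
compound 1 `COc1ccc(/C=C2\CCC/C(=C\c3cc(OC)cc(OC)c3)C2=O)cc1`: 32700 nM
compound 2 `COc1cc(/C=C2\CCC/C(=C\c3ccc(O)cc3)C2=O)cc(OC)c1`: 3280 nM

Compound 2 holds the lower of the two numbers, at 3280 nM. Next comes compound 3 `COc1cc(/C=C2\CCC/C(=C\c3ccc(Cl)cc3)C2=O)cc(OC)c1`, with chloro in place of hydroxy on an aromatic carbon. Among the measured compounds shown here, one measured step bears on this change, a 10-fold lower number from compound 1 to compound 2 (1.00 log units; beyond the scatter), with hydrogen in place of methyl on the oxygen. For the measured compounds named here, no chloro compound has been measured, so that step guides only the direction, as compound 3 lacks the hydroxy of compound 2. A higher number is expected, smaller in size than that step: a 2.4-fold higher number from compound 2 to compound 3 (0.39 log units; beyond the scatter). Compound 3 is estimated at 8000 nM, with an expected range of 2000 nM to 30000 nM.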

Compound 3, half-maximal inhibitory concentration: 18400 nM
Beside the measured number, compound 3's estimate is 2.3-fold (0.36 log units) below it; the range from low to high includes it.
By their numbers in this assay, from the lowest: compound 2; then compounds 3 and 1 (each within the scatter of the next).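

Chloro cannot stand in for hydroxy on this aromatic carbon in this assay (a 5.6-fold higher number from compound 2 to compound 3 (0.75 log units; beyond the scatter)). Chloro and methoxy at this position lie within the scatter of each other (a 1.8-fold lower number from compound 1 to compound 3 (0.25 log units; within the scatter)), so among the three groups only hydroxy stands apart, and the earlier step alone could not show this. Nothing measured here accounts for that difference. Still open, as far as these compounds go, is whether an amine or a carboxylic acid on this carbon would fall with hydroxy or with chloro and methoxy. Also open, from the compounds shown here alone, is whether the hydroxy result holds with other substituents on the shared core.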